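Chloro for methoxy on the pendant aryl of compound 1

The compounds below may be only part of what the source reports. "The series", "measured", "known", "first", "only" and "open" are said of these compounds alone.

Compound 1 `COc1ccc(-c2cs/c(=N\NC(=O)c3ccc(O)cc3)n2-c2ccc(OC)cc2OC)cc1` holds the lower of the two numbers in hand: in a functional assay on MCF7 cells (Homo sapiens) for cytotoxicity, read by sulforhodamine B assay, with a stated time of 48 h (on this read-out lower numbers stand for stronger inhibition of growth and higher numbers for weaker inhibition of growth), compound 1 gives 3720 nM, while compound 2 `Cc1ccc(-c2cs/c(=N\NC(=O)c3ccc(O)cc3)n2-c2c(C)cccc2C)cc1` gives 23400 nM. Compound 3 `COc1ccc(-n2c(-c3ccc(Cl)cc3)cs/c2=N\NC(=O)c2ccc(O)cc2)c(OC)c1` differs from compound 1 in a single place: chloro in place of methoxy on an aromatic carbon. Within the data shown here, no measured pair isolates that change, so its direction cannot be read from the data. The step of a 1.1-fold higher number from compound 1 to compound 3 (0.03 log units; within the scatter) is expected to stay within the scatter. Compound 3 is accordingly estimated in this assay at 4000 nM, with a range from 1500 nM to 11000 nM.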

Compound 3, concentration for 50% growth inhibition: 25100 nM
Beside the measured number, compound 3's estimate is 6.3-fold (0.80 log units) below it; measured number outside the range, above it.
By their numbers in this assay, from the lowest: compound 1; then compounds 2 and 3 (each within the scatter of the next).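

In this assay, among these compounds, the change from 4-methoxyphenyl to 4-chlorophenyl gives the first single-place comparison, and it is not silent: a 6.7-fold higher number from compound 1 to compound 3 (0.83 log units; beyond the scatter) shows that this position responds to substitution. Of the two groups, methoxy holds the lower number and so the stronger inhibition of growth. Nothing in hand explains the step.

One pair cannot separate the loss of methoxy from the arrival of chloro. Going by these compounds, whether a hydroxyl, an amine or an ethoxy on this aromatic carbon would stay close to compound 1 remains open.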